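The source may report more compounds than this note shows. Statements on the series, on what has been measured and on what is new or still open speak of the compounds shown alone.

Measured so far:
- compound 1 `Nc1ccccc1NC(=O)c1ccc(Cn2cnc3c(NCc4ccccc4)nc(Cl)nc32)cc1`: 5830 nM
- compound 2 `Nc1ccccc1NC(=O)c1ccc(Cn2cnc3c(Nc4ccc(-c5ccccn5)cc4)nc(Cl)nc32)cc1`: 18500 nM

In a functional assay on A-375 cells (Homo sapiens) for antiproliferative activity, read by CCK-8 assay, with a stated time of 72 h (on this read-out higher numbers stand for weaker inhibition and lower numbers for stronger inhibition), compound 2 gives 18500 nM, the higher of the two numbers and so the weaker inhibition. The next compound, compound 3 `Nc1ccccc1NC(=O)c1ccc(Cn2cnc3c(Nc4cccc(Cl)c4)nc(Cl)nc32)cc1`, keeps the shared core and changes one group: 3-chlorophenyl in place of 4-(pyridin-2-yl)phenyl on a nitrogen on an aromatic ring. In words, this is 3-chlorophenyl in place of 4-(pyridin-2-yl)phenyl on a nitrogen on an aromatic ring.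

Among the measured compounds shown here, only one measured step bears on this change. At the same place, the swap of benzyl for 4-(pyridin-2-yl)phenyl gave a 3.2-fold higher number from compound 1 to compound 2 (0.50 log units; beyond the scatter), a modest step beyond the usual scatter. For the measured compounds named here, no measured compound yet carries 3-chlorophenyl, so this single step is thin evidence. Removing the group that came with that rise should plausibly give a modest step of similar size towards a lower number. The expected change is a 2.6-fold lower number from compound 2 to compound 3 (0.42 log units; beyond the scatter). Compound 3 is expected at 7000 nM, with an estimated range from 2500 nM to 20000 nM.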

Compound 3, half-maximal inhibitory concentration: 6080 nM
Compound 3: the middle estimate sits 1.2-fold (0.06 log units) above what was measured, and the stated range covers the measured number.
By their numbers in this assay, from the lowest: compounds 1 and 3 (each within the scatter of the next); then compound 2.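

In this assay, putting 3-chlorophenyl in place of 4-(pyridin-2-yl)phenyl on this nitrogen gives a 3.0-fold lower number from compound 2 to compound 3 (0.48 log units; beyond the scatter). So the higher number seen with the two-ring group is not fixed at this position: a group with a single ring brings it back down. Set against benzyl, 3-chlorophenyl gives a 1.0-fold higher number from compound 1 to compound 3 (0.02 log units; within the scatter), so these two groups cannot be told apart in this assay, and of the three compounds only compound 2 stands apart. Nothing available explains these differences. Still open, as far as these compounds go, is whether the chlorine itself matters, and how a plain phenyl, or a phenyl carrying an amine or a carboxylic acid, would read at this nitrogen.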